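The source may report more compounds than this note shows. Statements on the series, on what has been measured and on what is new or still open speak of the compounds shown alone.

Of the compounds shown here, two with a shared core have been measured in a functional assay on A549 cells (Homo sapiens) for inhibition, read by CCK-8 assay, with a stated time of 48 h; on this read-out lower numbers stand for stronger inhibition and higher numbers for weaker inhibition. Compound 1 (`COc1cc(-c2ccnc3cc(-c4ccc(N(C)C)cc4)nn23)cc(OC)c1OC`) gives 1100 nM and compound 2 (`C=Cc1ccc(-c2cc3nccc(-c4cc(OC)c(OC)c(OC)c4)n3n2)cc1`) gives 1030 nM, so compound 2 stands level with compound 1, within the scatter of repeated measurements. Compound 3 (`COc1cc(-c2ccnc3cc(-c4cccc(C)c4)nn23)cc(OC)c1OC`) has yet to be measured. The change from compound 2 to compound 3 is this: 3-methylphenyl in place of 4-vinylphenyl on an aromatic carbon. It sits on an aromatic carbon of a five-membered aromatic ring with 2 nitrogen, and the 3-methylphenyl group has no measured precedent among these compounds. Within the data shown here, only one measured step bears on it, a 1.1-fold lower number from compound 1 to compound 2 (0.03 log units; within the scatter), which put vinyl in place of dimethylamino on an aromatic carbon of the same aryl group and stayed within the scatter. That single step is thin evidence, but it gives no reason to expect a large move or to favour a direction in this assay. The expected change is therefore no more than the scatter, an estimated 1.0-fold lower number from compound 2 to compound 3 (0.01 log units; within the scatter). For compound 3 the estimated value is 1000 nM, with an expected range of 350 nM to 3200 nM.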

Compound 3, half-maximal inhibitory concentration: 5730 nM
Compound 3: middle estimate off by 5.7-fold (0.76 log units), on the low side, outside the stated range (above it).
By their numbers in this assay, from the lowest: compounds 2 and 1 (each within the scatter of the next); then compound 3.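

In this assay, this position on the five-membered aromatic ring with 2 nitrogen turns out to respond to the aryl group it carries: 3-methylphenyl in place of 4-vinylphenyl gives a 5.6-fold higher number from compound 2 to compound 3 (0.75 log units; beyond the scatter) and 3-methylphenyl in place of 4-(dimethylamino)phenyl gives a 5.2-fold higher number from compound 1 to compound 3 (0.72 log units; beyond the scatter) as well. Both steps lie beyond the scatter, whereas the earlier exchange of dimethylamino for vinyl on the same aryl group stayed within it, so the tolerance seen between the two 4-substituted phenyl groups does not extend to 3-methylphenyl. Nothing available here explains the weaker inhibition of compound 3.

Because 3-methylphenyl differs from both other groups in the substituent and in its numbered place on the phenyl ring, the compounds shown leave open which of the two goes with the higher number, a question that 4-methylphenyl or 3-vinylphenyl could answer. They also leave open how this position would respond to other aryl groups, such as 4-methoxyphenyl or 4-carboxyphenyl.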